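The source may hold more compounds than are shown below. What is called first, only, known or untested is meant among the compounds shown, and "the series" means these compounds.

Measured compounds:
compound 1, `COc1ccc(S(=O)(=O)Oc2ccccc2NC(=O)Nc2ccccc2)cc1` — in a functional assay on NCI-H460 cells (Homo sapiens) for antiproliferative activity (on this read-out higher numbers stand for weaker inhibition and lower numbers for stronger inhibition), compound 1 gives > 10000 nM, a limit of the assay.
compound 2, `COc1ccc(S(=O)(=O)Oc2ccccc2NC(=O)c2ccc(N(C)C)cc2)cc1` — in this assay compound 2 gives > 10000 nM, likewise only a limit.

Compound 2 therefore stands at the upper edge of what this assay reports, and so does compound 1, both sitting at the limit of > 10000 nM in this assay, at which 2 of the 2 values shown sit. Among the compounds with values here, the one measured step, a step that the two limits leave unreadable from compound 1 to compound 2, cannot be sized, since both ends are limits. Compound 3, `COc1ccc(S(=O)(=O)Oc2ccccc2NC(=O)c2cccnc2)cc1`, differs from compound 2 by pyridin-3-yl in place of 4-(dimethylamino)phenyl on a carbonyl carbon. Within the data shown here, the only step that touches the same carbonyl carbon is that unreadable one, so no direction and no size can be drawn from it for this assay. Compound 3 is expected to remain at or near the limit, an expected step that the limit leaves unreadable from compound 2 to compound 3. Compound 3 is estimated at 20000 nM, within 5000 nM to 100000 nM.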

Compound 3, half-maximal inhibitory concentration: > 6000 nM
Compound 3 was reported as a limit; the forecaster's own chance of this, stated with the estimate: 80%; the middle value is on the limit's open side.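

In this assay compound 3 gives > 6000 nM, a limit of the assay. Compound 1 and compound 2 are also reported only as limits, so no step among these compounds can be read. They leave open whether the group on the carbonyl carbon changes antiproliferative activity at all.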